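Replacing Vinyl with (Phenylsulfanyl)methyl on the Shared Core

This account rests on a few compounds, and the source may have more. Where it says the series, first, only, none or still open, it means among the compounds named here.

Measured so far:
compound 1 `C=CCn1nc(-c2cccnc2)c2ccccc2c1=O` — 2140 nM
compound 2 `O=c1c2ccccc2c(-c2cccnc2)nn1S(=O)(=O)c1ccccc1` — 14800 nM

Of the compounds shown here, two on the shared core have been tested in a functional assay (trachea) with Cavia porcellus as the target; on this read-out higher numbers stand for weaker inhibition and lower numbers for stronger inhibition. Compound 1 stands lowest of the two numbers, giving 2140 nM. Compound 2, the nearest, gives 14800 nM, a gap that lies beyond the usual scatter, so compound 1 is the stronger inhibitor of the pair.

Compound 3 `O=c1c2ccccc2c(-c2cccnc2)nn1CCSc1ccccc1` is the next candidate. It differs from compound 1 by (phenylsulfanyl)methyl in place of vinyl on a saturated chain carbon bound to an aromatic nitrogen. Among the compounds with values here, no measured pair shares this change, so the expectation rests only on compound 1 and the broad spread seen with compound 2. The step of a 1.4-fold higher number from compound 1 to compound 3 (0.15 log units; within the scatter) is expected to be small, leaning toward a weaker number but not clearly beyond the scatter. Compound 3 is therefore estimated at 3000 nM, within a range of 800 nM to 12000 nM.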

Compound 3, half-maximal inhibitory concentration: 9120 nM
Compound 3: the middle estimate sits 3.0-fold (0.48 log units) below what was measured; low and high end bracket the measured number.
By their numbers in this assay, from the lowest: compound 1; then compounds 3 and 2 (each within the scatter of the next).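

In this assay, putting (phenylsulfanyl)methyl in place of vinyl on a saturated chain carbon bound to an aromatic nitrogen gives a 4.3-fold higher number from compound 1 to compound 3 (0.63 log units; beyond the scatter) and so weakens inhibition. Within the data shown here, this is the first single-place change on the shared core, and it shows that the number responds to what sits at this position. The entering group brings a sulfur and a six-membered aromatic ring together, so this one step cannot say which of them matters, and nothing measured here explains the shift.

Still open, on these data alone, is whether the loss follows from the sulfur, from the ring or from the larger group as a whole. A benzyl group, a plain butyl chain or a chain ending in an amine at this place could begin to separate these possibilities.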